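A few compounds are considered here, and "the series" means these few. Any claim that something is new, unique, unknown or untested is made for them only; others in the source may bear on it.

Measured in a functional assay on OVCAR-3 cells (Homo sapiens) for antiproliferative activity, read by sulforhodamine B assay, with a stated time of 72 h; a higher number here means a weaker inhibitor, a lower number a stronger inhibitor:
- compound 1 `O=C1CS/C(=N/Nc2nncc3ccccc23)N1c1ccccc1`: 44 nM
- compound 2 `Clc1ccc(C(/C=C/c2ccccc2)=N\Nc2nncc3ccccc23)cc1`: 5.4 nM
- compound 3 `O=S(=O)(Nc1nccs1)c1ccc(Nc2nncc3ccccc23)cc1`: 43 nM

Compound 3, at 43 nM, stands level with compound 1 at 44 nM, the two lying within the scatter of each other. Compound 2, at 5.4 nM, has a lower number than compound 3, and that gap lies beyond the scatter.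

The next compound is compound 4 `NS(=O)(=O)c1ccc(Nc2nncc3ccccc23)cc1`, which keeps the frame of compound 3 but loses the ring on the sulfonamide: hydrogen in place of 1,3-thiazol-2-yl on a sulfonamide nitrogen. In words, this is hydrogen in place of 1,3-thiazol-2-yl on a sulfonamide nitrogen.

For the measured compounds named here, no two measured compounds differ in one place, so the data give no direct size for such a step. The guide is thin: compound 1 at 44 nM and compound 3 at 43 nM carry different groups on the shared core yet stay within the scatter of each other, while compound 2 at 5.4 nM goes against that calm. A modest move towards a weaker inhibitor in this assay is therefore expected, close to the scatter, and the estimated size is a 1.4-fold higher number from compound 3 to compound 4 (0.14 log units; within the scatter). For compound 4 the expected value is 60 nM, with an estimated range from 15 nM to 250 nM.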

Compound 4, half-maximal inhibitory concentration: 14 nM
Compound 4: middle estimate off by 4.3-fold (0.63 log units), on the high side, and the stated range ends above it.
By their numbers in this assay, from the lowest: compound 2; then compound 4; then compounds 3 and 1 (each within the scatter of the next).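

Taking the 1,3-thiazol-2-yl group off the sulfonamide nitrogen gives the only direct measure of a single change among these compounds: in this assay, hydrogen in its place brings a 3.1-fold lower number from compound 3 to compound 4 (0.49 log units; beyond the scatter), a modest step that lies beyond the usual scatter. For the compounds shown here, the comparison shows that this position is not indifferent to what it carries, something the earlier compounds, which differ in more than one place, could not show. It also shows that the five-membered aromatic ring, with its 5 heavy atoms, is not required for activity in this pair, as the unsubstituted sulfonamide gives the lower number; nothing measured here accounts for this step.

A single pair cannot say whether any group on this nitrogen would raise the number or only the 1,3-thiazol-2-yl group does, so the compounds shown leave open how a methyl, an acetyl or a phenyl group would compare with hydrogen there. Also open, as far as these compounds go, is whether a pyridine ring in place of the 1,3-thiazol-2-yl group would give a number nearer that of compound 3 or compound 4.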